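The compounds below may be only part of what the source reports. "The series", "measured", "known", "first", "only" and "open" are said of these compounds alone.

compound 1 `c1ccc(-c2csc(Nc3ccc4c(c3)OCCO4)n2)nc1` – 55600 nM
compound 2 `Cc1ccc(Nc2nc(-c3ccccn3)cs2)nc1` – 34300 nM

In an ADME assay on KB cells (Homo sapiens) for cytotoxicity, read by MTT assay, with a stated time of 72 h (on this read-out lower numbers stand for higher toxicity in this test and higher numbers for lower toxicity in this test), compound 2 gives 34300 nM and so stands within the usual scatter of compound 1, with no clear gap between them. Compound 3 `COc1ccc(Nc2nc(-c3ccccn3)cs2)nc1` differs from compound 2 by having methoxy in place of methyl on an aromatic carbon and nothing else. Among the measured compounds shown here, no measured pair shows what such a swap does, so no step beyond the scatter is expected. The expected change is a 1.1-fold higher number from compound 2 to compound 3 (0.04 log units; within the scatter) in size. For compound 3 the estimated value is 38000 nM with an expected range from 15000 nM to 90000 nM as its likely span.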

Compound 3, half-maximal cytotoxic concentration in the KB assay: 13200 nM
Beside the measured number, compound 3's estimate is 2.9-fold (0.46 log units) above it; the whole stated range lies above it.
By their numbers in the KB assay, from the lowest: compound 3; then compounds 2 and 1 (each within the scatter of the next).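

At this place, on an aromatic carbon two atoms from the ring nitrogen, the group does matter: in the KB assay, methoxy in place of methyl gives a 2.6-fold lower number from compound 2 to compound 3 (0.41 log units; beyond the scatter), so compound 3 is the more toxic of the pair in this test. Among the compounds shown here, no earlier pair showed any step for this swap. In a physicochemical assay for solubility, in phosphate buffer, with a stated time of 2 h, at pH 7.4 (a higher number here means a more soluble compound, a lower number a less soluble compound), compound 2 gives 10000 nM and compound 3 gives 40000 nM after the swap. In the physicochemical assay, the same swap also goes with more compound in solution: the measured solubility of compound 2, 10000 nM, and of compound 3, 40000 nM, a 4.0-fold higher number (0.60 log units; beyond the scatter)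

Going by these compounds, what an amine or an ethoxy group at this place would do to toxicity and solubility stays open. So does whether methoxy would act alike on a different core.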